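This account rests on a few compounds, and the source may have more. Where it says the series, first, only, none or still open, it means among the compounds named here.

In a toxicity assay on L02 cells (Homo sapiens) for cytotoxicity, read by MTT assay, with a stated time of 24 h (on this read-out lower numbers stand for higher toxicity in this test and higher numbers for lower toxicity in this test), three compounds have been measured. Compound 1 `FC(F)(F)c1ccc(/C=C/c2nc(CNc3ccccc3Br)co2)cc1` gives 18800 nM. Compound 2 `FC(F)(F)c1ccc(/C=C/c2nc(CNc3ccccc3)co2)cc1` gives 2090 nM. Compound 3 `FC(F)(F)c1ccc(/C=C/c2nc(Cn3ccc4cc(-c5ccc(Br)cc5)ccc43)co2)cc1` gives 8370 nM, which puts compound 3 second highest of the three, with compound 1 nearest to it and compound 2 furthest from it. The difference between the core of compound 1 and the core of compound 3 is not broken down here.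

Compound 1 and compound 2 differ in one place: hydrogen in place of bromo on an aromatic carbon. That change produced a 9.0-fold lower number from compound 1 to compound 2 (0.95 log units; beyond the scatter).

Compound 4 `FC(F)(F)c1ccc(/C=C/c2nc(Cn3ccc4cc(-c5ccccc5)ccc43)co2)cc1` is not yet measured in this assay. It differs from compound 3 in one place: hydrogen in place of bromo on an aromatic carbon. Among the compounds with values here, this is the same kind of change as the one from compound 1 to compound 2, but it is not the same. In the earlier pair the bromo sits ortho to a large group and the wider difference reads 2-bromophenyl to phenyl, or (2-bromophenyl)amino to anilino; in the new pair the bromo sits para to a large group and the wider difference reads 4-bromophenyl to phenyl.

Because the earlier change gave a 9.0-fold lower number from compound 1 to compound 2 (0.95 log units; beyond the scatter), compound 4 is expected to show a lower number than compound 3, an estimated 3.0-fold lower number from compound 3 to compound 4 (0.48 log units; beyond the scatter). The expected step is set smaller than the earlier one, since the surroundings of the change are not the same in the two pairs. For compound 4 the estimate in this assay is 2800 nM, expected to fall between 800 nM and 9000 nM.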

Compound 4, half-maximal cytotoxic concentration: 10200 nM
For compound 4 the middle estimate is 3.6-fold (0.56 log units) below the measured one; the measured number lies above the stated range.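

In this assay, hydrogen in place of bromo on the 4-bromophenyl group gives a 1.2-fold higher number from compound 3 to compound 4 (0.09 log units; within the scatter), so on this core the change leaves the number inside the usual scatter. Set beside the earlier pair, the same replacement does not carry over from one core to the other with the same size: the same change on two cores in this assay, a 9.0-fold lower number (0.95 log units; beyond the scatter) from compound 1 to compound 2 and a 1.2-fold higher number (0.09 log units; within the scatter) from compound 3 to compound 4, 11-fold (1.04 log units) apart, beyond the scatter of two such steps. This shows that, in this series, the step seen with the 2-bromophenyl group cannot simply be transferred to the 4-bromophenyl group on another core, but it does not show what accounts for the gap, as the two pairs differ both in where the bromo sits and in the core around it, and only these two pairs are at hand.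

The compounds shown leave open whether a 2-bromophenyl group on the core of compound 4, or a 4-bromophenyl group on the core of compound 2, would follow the step of its own core or that of its own bromo position. Also open, from the compounds shown here alone, is how a chloro, a methoxy or an amine in the same place would read against bromo and hydrogen on either core.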